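The source may hold more compounds than are shown below. What is called first, only, known or untested is meant among the compounds shown, and "the series" means these compounds.

Compound 3 `CC(C)/C=C/C(=O)Nc1cccc(Oc2nc(Nc3cccc(C#N)c3)nc3ccsc23)c1` gives 24100 nM in a functional assay on A-431 cells (Homo sapiens) for inhibition, read by MTT assay, with a stated time of 72 h (a lower number here means a stronger inhibitor, a higher number a weaker inhibitor), the highest of the three numbers measured, though its gap to compound 2 lies within the scatter. Compound 1 `C=CC(=O)Nc1cccc(Oc2nc(Nc3cccc(C#N)c3)nc3ccsc23)c1` gives 3790 nM, and compound 2 `C/C=C/C(=O)Nc1cccc(Oc2nc(Nc3cccc(C#N)c3)nc3ccsc23)c1` gives 20100 nM. The steps of a 5.3-fold higher number from compound 1 to compound 2 (0.72 log units; beyond the scatter) and a 6.4-fold higher number from compound 1 to compound 3 (0.80 log units; beyond the scatter) both lie beyond the scatter, whereas the step of a 1.2-fold higher number from compound 2 to compound 3 (0.08 log units; within the scatter) lies within it. Compound 4 `CCC/C=C/C(=O)Nc1cccc(Oc2nc(Nc3cccc(C#N)c3)nc3ccsc23)c1` differs from compound 3 by propyl in place of isopropyl on a double-bonded chain carbon bound to a double-bonded chain carbon. For the measured compounds named here, the only precedent at this position is the step from compound 2 to compound 3, which stayed within the scatter; the larger steps start from compound 1 and concern another change. Compound 4 is therefore expected to show a 1.1-fold lower number from compound 3 to compound 4 (0.04 log units; within the scatter) in this assay, nothing beyond the scatter. Compound 4 is estimated at 22000 nM, within a range from 9000 nM to 55000 nM.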

Compound 4, half-maximal inhibitory concentration: 20400 nM
Compound 4: middle estimate off by 1.1-fold (0.03 log units), on the high side, within the range that was stated.
By their numbers in this assay, from the lowest: compound 1; then compounds 2, 4 and 3 (each within the scatter of the next).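

In this assay, propyl in place of isopropyl stays within the scatter, a 1.2-fold lower number from compound 3 to compound 4 (0.07 log units; within the scatter), and ethyl in place of hydrogen on a saturated chain carbon does too, a 1.0-fold higher number from compound 2 to compound 4 (0.01 log units; within the scatter), so the length and shape of this chain do not separate compound 2, compound 3 and compound 4. The step of a 5.4-fold higher number from compound 1 to compound 4 (0.73 log units; beyond the scatter) lies beyond the scatter, like the other steps away from vinyl. Nothing available explains these steps. Open, going by these compounds, is whether a dimethylamino group or a phenyl ring on this chain would leave the number unchanged.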